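The source may hold more compounds than are shown below. What is called first, only, known or untested is meant among the compounds shown, and "the series" means these compounds.

Measured compounds in an ADME assay on MDBK cells (Bos taurus) for cytotoxicity, read by MTT assay; on this read-out higher numbers stand for lower toxicity in this test and lower numbers for higher toxicity in this test:
compound 1, `OC[C@@H]1[C@@H](O)[C@H](O)[C@@H](O)CN1CCCCCCOc1ccc(C(F)(F)F)cc1`: > 500000 nM.
compound 2, `CC1CCCC(OCCCCCCN2C[C@H](O)[C@@H](O)[C@H](O)[C@H]2CO)C1C`: > 500000 nM.

For compound 1 the result in this assay is only a limit of the test, > 500000 nM, not a number. For compound 2 the result is likewise only a limit, > 500000 nM. For the measured compounds named here, compound 2 therefore stands exactly where the only other measured compound stands, at the limit of > 500000 nM in this assay, at which 2 of the 2 values shown sit, and no difference between the two can be read from these values.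

Compound 3, `CCC1CCC(OCCCCCCN2C[C@H](O)[C@@H](O)[C@H](O)[C@H]2CO)CC1`, differs from compound 2 in one place: a group of 8 heavy atoms (8 carbon; one six-membered non-aromatic ring of carbon only) in place of a group of 8 heavy atoms (8 carbon; one six-membered non-aromatic ring of carbon only), on an oxygen on a saturated carbon. Going by the values given here, no step between measured compounds is available to gauge such a change, so the expectation is a step of no size beyond the usual scatter, in no particular direction. Compound 3 is accordingly expected to sit again at the limit, with an estimate of 500000 nM and a range from 200000 nM to 1000000 nM. The expected a number no higher from compound 2 to compound 3 (the limit leaves the size open) is estimated to stay within the scatter.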

Compound 3, half-maximal cytotoxic concentration: > 500000 nM
Compound 3: only a limit was reported; the forecaster's own chance of this, stated with the estimate: 85%; the middle value sits exactly at the limit.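

For the compounds shown here, no step from compound 2 to compound 3 can be read in this assay, since both results are only limits of the test, not numbers. The compounds shown leave open what the actual values of all three compounds are, and whether they differ from one another at all.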